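A few compounds are considered here, and "the series" means these few. Any claim that something is new, unique, unknown or untested is made for them only; others in the source may bear on it.

Measured so far:
- compound 1 `COc1ccc(-c2nc3cccc(-c4cc(OC)c(OC)c(OC)c4)c3o2)cc1OC` gives 1300 nM in a functional assay on U-251 cells (Homo sapiens) for antiproliferative activity, read by MTT assay, with a stated time of 48 h; a lower number here means a stronger inhibitor, a higher number a weaker inhibitor
- compound 2 `COc1cc(-c2cccc3nc(-c4ccc(Cl)cc4)oc23)cc(OC)c1OC` gives 1600 nM in this assay

On these two numbers compound 2 has no rank of its own, as it lies within the scatter of compound 1. The next change leads to compound 3 `COc1cc(-c2cccc3nc(-c4ccc5cc[nH]c5c4)oc23)cc(OC)c1OC` and is described as 1H-indol-6-yl in place of 4-chlorophenyl on an aromatic carbon with the new group on the aromatic carbon next to the ring nitrogen and next to the ring oxygen. Among the compounds with values here, the one measured step that bears on this place is a 1.2-fold higher number from compound 1 to compound 2 (0.09 log units; within the scatter) and it swapped the group at that same carbon. That step is a weak guide, as neither compound 1 nor compound 2 carries a group like 1H-indol-6-yl. The data therefore fix no direction firmly. A moderate move to a lower number in this assay is expected, held loosely and with a wide range on both sides. For compound 3 the estimated value is 600 nM with an expected range from 80 nM to 3000 nM as a working figure. This estimate means an expected 2.7-fold lower number from compound 2 to compound 3 (0.43 log units; beyond the scatter) for now.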

Compound 3, half-maximal inhibitory concentration: 300 nM
The estimate for compound 3 lay 2.0-fold (0.30 log units) above the measured number; measured number inside the range.
By their numbers in this assay, from the lowest: compound 3; then compounds 1 and 2 (each within the scatter of the next).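

In this assay, the aromatic carbon next to the ring nitrogen and next to the ring oxygen now proves responsive to the group it carries: 1H-indol-6-yl in place of 4-chlorophenyl gives a 5.3-fold lower number from compound 2 to compound 3 (0.73 log units; beyond the scatter), and 1H-indol-6-yl in place of 3,4-dimethoxyphenyl gives a 4.3-fold lower number from compound 1 to compound 3 (0.64 log units; beyond the scatter). The exchange between the two substituted phenyl groups had stayed within the scatter, whereas the group with a five-membered aromatic ring and one hydrogen-bond donor separates from both, though both steps are modest. Nothing available accounts for this difference or ties it to a measured property of the group.

The three compounds cannot separate the added five-membered ring from the hydrogen-bond donor, since both enter together; naphthalen-2-yl and 1-methyl-1H-indol-6-yl at this carbon would pull the two apart. Also open, going by these compounds, is whether the indolyl attachment point matters, as with 1H-indol-5-yl, and how far this carbon tolerates an open-chain aminoalkyl group or a carboxylic acid on the ring.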